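The compounds below may be only part of what the source reports. "The series", "measured", "known", "first", "only" and "open" are said of these compounds alone.

Compound 3 `O=Cc1cc([N+](=O)[O-])ccc1OCc1cn(CCCOc2ccc3ccc(=O)oc3c2)nn1` gives 53600 nM in a functional assay on HT-29 cells (Homo sapiens) for cytotoxicity, read by MTT assay, with a stated time of 24 h (on this read-out higher numbers stand for weaker inhibition and lower numbers for stronger inhibition), the second highest of the three numbers; compound 2 `O=Cc1cccc(OCc2cn(CCCOc3ccc4ccc(=O)oc4c3)nn2)c1` gives 129000 nM and compound 1 `O=Cc1ccccc1OCc1cn(CCCOc2ccc3ccc(=O)oc3c2)nn1` gives 18900 nM. Compound 4 `COc1cc(C=O)ccc1OCc1cn(CCCOc2ccc3ccc(=O)oc3c2)nn1` carries 4-formyl-2-methoxyphenyl in place of 2-formyl-4-nitrophenyl on an oxygen on a saturated carbon. For the measured compounds named here, two measured steps bear on it: a 2.8-fold higher number from compound 1 to compound 3 (0.45 log units; beyond the scatter), and a 6.8-fold higher number from compound 1 to compound 2 (0.83 log units; beyond the scatter); a 2.4-fold lower number from compound 2 to compound 3 (0.38 log units; beyond the scatter) combines both. Going by the values given here, the nitro leaving compound 3 points toward a lower number, while the changed placement of the formyl and the added methoxy have no counterpart among the measured compounds. The expected net effect is therefore a 1.3-fold lower number from compound 3 to compound 4 (0.13 log units; within the scatter), a modest shift with wide uncertainty. Compound 4 is expected to give about 40000 nM in this assay, within a range from 12000 nM to 150000 nM.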

Compound 4, half-maximal inhibitory concentration: 65400 nM
Beside the measured number, compound 4's estimate is 1.6-fold (0.21 log units) below it; measured number inside the range.
By their numbers in this assay, from the lowest: compound 1; then compounds 3, 4 and 2 (each within the scatter of the next, the first and the last beyond it).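

In this assay, at this place on an oxygen on a saturated carbon, 4-formyl-2-methoxyphenyl cannot be told apart from 2-formyl-4-nitrophenyl, with a 1.2-fold higher number from compound 3 to compound 4 (0.09 log units; within the scatter), or from 3-formylphenyl, with a 2.0-fold lower number from compound 2 to compound 4 (0.30 log units; within the scatter). Only 2-formylphenyl separates from the new group, with a 3.5-fold higher number from compound 1 to compound 4 (0.54 log units; beyond the scatter), so among the four compounds compound 1 alone stands beyond the scatter of all the others. Nothing measured here bears on why the numbers fall this way.

Open, from the compounds shown here alone, is whether a carboxylic acid or an amine in place of the formyl would stay with compound 1 or with the other three.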